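This account rests on a few compounds, and the source may have more. Where it says the series, first, only, none or still open, it means among the compounds named here.

Compound 1 `OC1(CNCc2ccccc2)CCN(CCCc2c[nH]c3ccc(-n4cnnc4)cc23)CC1`: 0.45 nM
Compound 2 `Cc1ccccc1CNCC1(O)CCN(CCCc2c[nH]c3ccc(-n4cnnc4)cc23)CC1`: 4 nM
Compound 3 `CN(Cc1ccccc1)CC1(O)CCN(CCCc2c[nH]c3ccc(-n4cnnc4)cc23)CC1`: 1.2 nM

In an assay on CHO cells with 5-hydroxytryptamine receptor 1D (Homo sapiens) as the target (on this read-out lower numbers stand for stronger inhibition and higher numbers for weaker inhibition), compound 3 holds the second highest number of the three measured compounds. Compound 4 `CC(=O)Nc1ccc(CNCC2(O)CCN(CCCc3c[nH]c4ccc(-n5cnnc5)cc34)CC2)cc1` has not yet been measured; the change from compound 3 is (4-acetamidobenzyl)amino in place of benzyl(methyl)amino on a saturated chain carbon bound to a saturated ring carbon. Going by the values given here, two measured steps bear on it. a 2.7-fold higher number from compound 1 to compound 3 (0.43 log units; beyond the scatter) shows that a methyl added on the amine nitrogen raised the number, so removing it again should lower it. an 8.9-fold higher number from compound 1 to compound 2 (0.95 log units; beyond the scatter) shows a methyl on the aromatic ring raising the number, but the acetamido group entering here is a different group, so that step gives no direct guide. For compound 4 in this assay a modest fall is therefore expected, a 1.5-fold lower number from compound 3 to compound 4 (0.18 log units; within the scatter). Compound 4 is estimated at 0.8 nM, with an expected range from 0.2 nM to 4 nM.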

Compound 4, half-maximal inhibitory concentration: 11 nM
Compound 4: the middle estimate sits 14-fold (1.14 log units) below what was measured; measured number outside the range, above it.
By their numbers in this assay, from the lowest: compound 1; then compound 3; then compound 2; then compound 4.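

In this assay, adding acetamido to the benzyl ring of compound 1 gives a 24-fold higher number from compound 1 to compound 4 (1.39 log units; beyond the scatter) as the largest step among these compounds. The (4-acetamidobenzyl)amino group also falls behind the other groups at this place, with a 2.8-fold higher number from compound 2 to compound 4 (0.44 log units; beyond the scatter) against the ring methyl and a 9.2-fold higher number from compound 3 to compound 4 (0.96 log units; beyond the scatter) against benzyl(methyl)amino. Nothing available explains this loss. Still open, going by these compounds, is whether it belongs to acetamido alone or to any ring group at this place. An amine or a methoxy group on the same ring could separate these two readings.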